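Notes on the step from compound 3 to compound 4

The compounds below may be only part of what the source reports. "The series", "measured", "known", "first", "only" and "open" are said of these compounds alone.

The series shares one core and varies the group on a triple-bonded carbon. In a functional assay on BaF3 cells (Mus musculus) for antiproliferative activity (on this read-out lower numbers stand for an effect already at smaller amounts and higher numbers for an effect only at larger amounts of compound), compound 1 `CCN1CCN(Cc2ccc(NC(=O)c3ccc(C)c(C#Cc4ccc(C(=O)NC)nc4)c3)cc2C(F)(F)F)CC1` gives 3980 nM, compound 2 `CCN1CCN(Cc2ccc(NC(=O)c3ccc(C)c(C#Cc4cnc(N)cn4)c3)cc2C(F)(F)F)CC1` gives 860 nM and compound 3 `CCN1CCN(Cc2ccc(NC(=O)c3ccc(C)c(C#Cc4cnc5[nH]ccc5c4)c3)cc2C(F)(F)F)CC1` gives 1000 nM. Compound 3 therefore belongs to the lower pair of these numbers, and the pair cannot be separated: the data show a 1.2-fold higher number from compound 2 to compound 3 (0.07 log units; within the scatter). Compound 1 stands apart, with a 4.6-fold lower number from compound 1 to compound 2 (0.67 log units; beyond the scatter) and a 4.0-fold lower number from compound 1 to compound 3 (0.60 log units; beyond the scatter), both modest.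

Compound 4 `CCN1CCN(Cc2ccc(NC(=O)c3ccc(C)c(C#Cc4cnc5nccnc5c4)c3)cc2C(F)(F)F)CC1` carries a group of 10 heavy atoms (7 carbon, 3 nitrogen; one six-membered aromatic ring with 1 hetero atom, one six-membered aromatic ring with 2 hetero atoms) in place of a group of 9 heavy atoms (7 carbon, 2 nitrogen; one five-membered aromatic ring with 1 hetero atom, one six-membered aromatic ring with 1 hetero atom), on a triple-bonded carbon. The entering group has 0 hydrogen-bond donors and 3 hydrogen-bond acceptors, and the leaving group has 1 of each. Within the data shown here, no measured step makes this exact exchange, so any guidance is indirect. The closest guide is a 1.2-fold higher number from compound 2 to compound 3 (0.07 log units; within the scatter), an exchange of one group for another of different size that left the number within the scatter. The two modest steps both start from compound 1 and say little about a change that starts from compound 3. No step beyond the scatter is therefore expected in this assay, and the expected step is a 1.2-fold higher number from compound 3 to compound 4 (0.08 log units; within the scatter). Among the measured compounds shown here, with only three measured compounds, the range is kept wide. Compound 4 is estimated at 1200 nM, with an expected range from 400 nM to 3500 nM.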

Compound 4, half-maximal effective concentration: 3320 nM
Estimate against measurement, compound 4: 2.8-fold (0.44 log units) below; low and high end bracket the measured number.
By their numbers in this assay, from the lowest: compounds 2 and 3 (each within the scatter of the next); then compounds 4 and 1 (each within the scatter of the next).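

In this assay, the exchange on the triple-bonded carbon of a group with one five-membered and one six-membered aromatic ring for a group with two six-membered aromatic rings gives a 3.3-fold higher number from compound 3 to compound 4 (0.52 log units; beyond the scatter) and so shows that two-ring groups at this place are not interchangeable. With the same entering group, the data show a 3.9-fold higher number from compound 2 to compound 4 (0.59 log units; beyond the scatter) and also a 1.2-fold lower number from compound 1 to compound 4 (0.08 log units; within the scatter) so that the series now falls into two sets, with compounds 2 and 3 carrying groups of 7 and 9 heavy atoms and compounds 1 and 4 carrying groups of 10 heavy atoms, an order that no compound shown goes against, though four compounds are too few to establish it. Nothing measured here accounts for the shift.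

The step from compound 3 to compound 4 changes heavy-atom count, ring make-up and hydrogen-bond donor count together, so the compounds shown do not tell which of these matters. On these data alone, how a plain phenyl or an unsubstituted pyridin-3-yl on the triple-bonded carbon would fall against these two sets remains open.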